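From phenyl to 4-ethylphenyl at the assay limit

The source may report more compounds than this note shows. Statements on the series, on what has been measured and on what is new or still open speak of the compounds shown alone.

Compound 1 `O=C(Nc1ccc(Oc2ccnc3[nH]ccc23)cc1)c1cc(-c2ccccc2)ccn1`: 3270 nM
Compound 2 `O=C(Nc1ccc(Oc2ccnc3[nH]ccc23)c(F)c1)c1cc(-c2ccccc2)ccn1`: > 10000 nM

Both compounds were tested in a functional assay on PC-3 cells (Homo sapiens) for cytotoxicity, read by MTT assay, with a stated time of 72 h; a higher number here means a weaker inhibitor, a lower number a stronger inhibitor. Compound 1 gives a measured number there. Compound 2 stands at > 10000 nM, which is a limit of the assay and not a number. Within the data shown here, the only measured step, an at least 3.0-fold higher number from compound 1 to compound 2 (0.48 log units; beyond the scatter), is fluoro in place of hydrogen on an aromatic carbon, which is a different change from the one at hand.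

Compound 3 `CCc1ccc(-c2ccnc(C(=O)Nc3ccc(Oc4ccnc5[nH]ccc45)c(F)c3)c2)cc1` differs from compound 2 by ethyl in place of hydrogen on an aromatic carbon, with ethyl in place of hydrogen on an aromatic carbon, so that phenyl becomes 4-ethylphenyl. Among the measured compounds shown here, no measured step covers this exchange, so the data give neither its size nor its direction. With compound 2 resting at the limit of > 10000 nM in this assay, at which 1 of the 2 values shown sits, no shift beyond the scatter is expected in this assay. The expected change is an at least 1.1-fold lower number from compound 2 to compound 3 (0.04 log units; that floor lies within the scatter). For compound 3 the estimated value is 9000 nM, with an expected range of 3000 nM to 20000 nM.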

Compound 3, half-maximal inhibitory concentration: 2960 nM
Compound 3: middle estimate off by 3.0-fold (0.48 log units), on the high side; the measured number lies below the stated range.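

At this position, on an aromatic carbon para to a large group, ethyl in place of hydrogen gives in this assay an at least 3.3-fold lower number from compound 2 to compound 3 (0.52 log units; beyond the scatter). Among these compounds, this is the first measured change at this site, and it shows that the site can take a substituent with a move towards stronger inhibition, with compound 3 reading 2960 nM. The size of the step is only a floor, because compound 2 rests at a limit of the assay: the limit of > 10000 nM in this assay, at which 1 of the 3 values shown sits.

On these data alone, it remains open whether the lower number belongs to ethyl itself or would also come with a methyl group, a longer chain or an amine at the same place. As far as these compounds go, it is also open whether ethyl would shift the number in the same way on compound 1, which carries no fluoro.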